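A few compounds are considered here, and "the series" means these few. Any claim that something is new, unique, unknown or untested is made for them only; others in the source may bear on it.

Compound 1 `CCCCCCOC(=O)c1cccc(-c2ccc(OCC)cc2)c1`: in an assay on COS-7 cells for inhibition of patatin-like phospholipase domain-containing protein 2 (Mus musculus) (on this read-out lower numbers stand for stronger inhibition and higher numbers for weaker inhibition), compound 1 gives > 200000 nM, which is a limit of the assay and not a number.
Compound 2 `CCOc1ccc(-c2cccc(C(=O)OCCOC)c2)cc1`: in this assay compound 2 gives 70000 nM.
Compound 3 `CCOc1ccc(-c2cccc(C(=O)OCCOCCOC)c2)cc1`: in this assay compound 3 gives > 200000 nM, again only a limit of the assay.

Compound 3 thus stands at the limit of > 200000 nM in this assay, at which 2 of the 3 values shown sit, and no number is known for it. Among the three esters, the tail matters: there is an at least 2.8-fold lower number from compound 1 to compound 2 (0.45 log units; beyond the scatter), then an at least 2.8-fold higher number from compound 2 to compound 3 (0.45 log units; beyond the scatter), while a step that the two limits leave unreadable from compound 1 to compound 3.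

Compound 4 `CCNC(=O)c1cccc(-c2ccc(OCC)cc2)c1` is not yet measured. It differs from compound 3 by ethylamino in place of 2-(2-methoxyethoxy)ethoxy on a carbonyl carbon. Within the data shown here, none of the measured steps touches the carbonyl carbon itself; they only exchange one ester tail for another, and two of the three values are limits. So the measured steps give no direct guide to this change, only the picture that the shared core is weak in this assay whatever tail it carries. Compound 4 is expected to stay in that weak range, with a real chance that the assay again reports only a limit. Compound 4 is therefore estimated at 100000 nM, in a range from 20000 nM to 300000 nM, which would mean an at least 2.0-fold lower number from compound 3 to compound 4 (0.30 log units; that floor lies within the scatter).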

Compound 4, half-maximal inhibitory concentration: 90000 nM
The estimate for compound 4 lay 1.1-fold (0.05 log units) above the measured number; the range from low to high includes it.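

Compound 4 shows that an ester tail on this carbonyl carbon is not needed for a readable number in this assay: with ethylamino there, the result is an at least 2.2-fold lower number from compound 3 to compound 4 (0.34 log units; beyond the scatter) and an at least 2.2-fold lower number from compound 1 to compound 4 (0.34 log units; beyond the scatter). Against the 2-methoxyethoxy tail the change gives a 1.3-fold higher number from compound 2 to compound 4 (0.11 log units; within the scatter), so in this assay ethylamino and 2-methoxyethoxy cannot be told apart, even though ethylamino brings one hydrogen-bond donor and no hydrogen-bond acceptors, whereas 2-methoxyethoxy is an ester tail. The other two tails, hexyloxy in compound 1 and 2-(2-methoxyethoxy)ethoxy in compound 3, remain bounded only by a limit of the assay: the limit of > 200000 nM in this assay, at which 2 of the 4 values shown sit.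

The compounds shown leave open whether a methylamino group, a longer alkylamino chain or a carboxylic acid on this carbonyl carbon would carry the number clearly beyond the level shared by compound 2 and compound 4. From the compounds shown here alone, the full size of the steps that start from or end at a limit also stays unknown, and any step between the two limits cannot be read.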